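The source may hold more compounds than are shown below. What is called first, only, known or untested is meant among the compounds shown, and "the series" means these compounds.

Measured so far in an assay on Sf21 cells for inhibition of ubiquitin carboxyl-terminal hydrolase 7 (Homo sapiens), read by spectrophotometry, with stated times of 30 min and 2 h; on this read-out lower numbers stand for stronger inhibition and higher numbers for weaker inhibition:
- compound 1 `O=c1c2cnn(-c3ccc(F)cc3)c2ncn1CC1(O)CCN(Cc2ccccc2F)CC1` gives 9800 nM
- compound 2 `O=c1c2cnn(-c3ccc(F)cc3)c2ncn1CC1(O)CCN(Cc2ccccc2Cl)CC1` gives 3400 nM
- compound 3 `O=c1c2cnn(-c3ccc(F)cc3)c2ncn1CC1(O)CCN(Cc2ccc(F)cc2Cl)CC1` gives 1600 nM

Compound 3 shows the lowest number of the three, with a 2.1-fold lower number from compound 2 to compound 3 (0.33 log units; beyond the scatter) and a 6.1-fold lower number from compound 1 to compound 3 (0.79 log units; beyond the scatter). Compound 4 `O=c1c2cnn(-c3ccc(F)cc3)c2ncn1CC1(O)CCN(Cc2ccc(Cl)cc2Cl)CC1` has not been measured yet. It differs from compound 3 by chloro in place of fluoro on an aromatic carbon. The change from compound 1 to compound 2 is the same kind of change, (chloro in place of fluoro on an aromatic carbon), and brought a 2.9-fold lower number from compound 1 to compound 2 (0.46 log units; beyond the scatter). The two cores differ by 2-chloro-4-fluorophenyl in place of 2-fluorophenyl on a saturated chain carbon bound to an amine nitrogen in a ring. The surroundings are not identical: in compound 1 the replaced fluoro sits ortho to a large group, whereas in compound 3 it sits meta to a chloro group and para to a large group, so the step may not carry over exactly. Compound 4 is expected to give a step of a 1.8-fold lower number from compound 3 to compound 4 (0.25 log units; within the scatter), resting on compound 2 and its step of a 2.9-fold lower number from compound 1 to compound 2 (0.46 log units; beyond the scatter). Compound 4 is estimated at 900 nM, between 350 nM and 2500 nM.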

Compound 4, half-maximal inhibitory concentration: 3300 nM
Compound 4: middle estimate off by 3.7-fold (0.56 log units), on the low side, outside the stated range (above it).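

In this assay, chloro in place of fluoro on an aromatic carbon did not carry over from one core to the other, and the direction of the step reversed: the same change on two cores in this assay, a 2.9-fold lower number (0.46 log units; beyond the scatter) from compound 1 to compound 2 and a 2.1-fold higher number (0.31 log units; beyond the scatter) from compound 3 to compound 4, 5.9-fold (0.77 log units) apart, beyond the scatter of two such steps

The result is a 2.1-fold higher number from compound 3 to compound 4 (0.31 log units; beyond the scatter), which leaves compound 4 level with compound 2, at a 1.0-fold lower number from compound 2 to compound 4 (0.01 log units; within the scatter), while a 3.0-fold lower number from compound 1 to compound 4 (0.47 log units; beyond the scatter) shows that it still reads better than the 2-fluorophenyl compound. Going by these compounds alone, these are only two pairs, so they show that this step cannot be assumed to transfer, but they do not explain the reversal or predict the step on any other core.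

Still open, going by these compounds, is how a methoxy group or a nitrile would read where compound 3 carries its fluoro.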